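Triazole in Place of Methylpiperazine: Predicting Compound 4

The source may report more compounds than this note shows. Statements on the series, on what has been measured and on what is new or still open speak of the compounds shown alone.

Compound 1, `CN1CCN(c2ccc(C3=NN(S(=O)(=O)c4ccc(Br)cc4)C(c4ccc(N(C)C)cc4)C3)cc2)CC1`: 23.7%
Compound 2, `CN1CCN(c2ccc(C3=NN(S(=O)(=O)c4ccc(C#N)cc4)C(c4ccc(N(C)C)cc4)C3)cc2)CC1`: 99.8%
Compound 3, `CN1CCN(c2ccc(C3=NN(S(=O)(=O)c4ccc(OC(F)(F)F)cc4)C(c4ccc(N(C)C)cc4)C3)cc2)CC1`: 10.6%

Of the compounds shown here, three have been measured in a functional assay on MDA-MB-231 cells (Homo sapiens) for inhibition, read by sulforhodamine B assay, tested at 10 uM; a higher number here means more inhibition at the concentration tested (going by the name of the read-out), a lower number less inhibition. Compound 1 stands second highest of the three numbers; compound 3 lies nearest to it and compound 2 furthest. The step of a number 76.1 percentage points higher from compound 1 to compound 2 (beyond the scatter) is large, the step of a number 13.1 percentage points lower from compound 1 to compound 3 (beyond the scatter) is modest, and the step of a number 89.2 percentage points lower from compound 2 to compound 3 (beyond the scatter) is again large. All three measured steps change the group on the aromatic ring attached to the sulfonyl group.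

Compound 4, `CN(C)c1ccc(C2CC(c3ccc(-n4cncn4)cc3)=NN2S(=O)(=O)c2ccc(Br)cc2)cc1`, is not yet measured in this assay. It differs from compound 1 elsewhere: 1H-1,2,4-triazol-1-yl in place of 4-methylpiperazin-1-yl on an aromatic carbon. Within the data shown here, none of the measured steps touches this position, so none bears directly on the change, and the direction of the step cannot be read from them. The measured compounds only show that a change of a single aromatic substituent can move the read-out in this assay by a large amount, so a wide range is warranted. Compound 4 is therefore expected to give about 25%, between 5% and 65%. This estimate implies an expected step of a number 1.3 percentage points higher from compound 1 to compound 4 (within the scatter), which is within the scatter.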

Compound 4, a percentage reported as inhibition, at one concentration (the size of the read-out at that concentration, not a potency): 10.4%
Estimate against measurement, compound 4: 14.6 percentage points above, and the stated range covers the measured number.
By their numbers in this assay, from the lowest: compounds 4 and 3 (each within the scatter of the next); then compound 1; then compound 2.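

In this assay the swap of 4-methylpiperazin-1-yl for 1H-1,2,4-triazol-1-yl gives a number 13.3 percentage points lower from compound 1 to compound 4 (beyond the scatter), which shows that the read-out also responds at this position and not only at the group on the ring attached to the sulfonyl. With bromo held constant, this change of a six-membered non-aromatic ring for a five-membered aromatic ring is a modest step, much smaller than the step of a number 76.1 percentage points higher from compound 1 to compound 2 (beyond the scatter) that comes with cyano in place of bromo. Nothing available explains the lower number.

Among these compounds, only one pair covers this position, so it remains open whether the triazole would lower the read-out from the high value of compound 2 at 99.8% in the same way. From the compounds shown here alone, how a morpholine ring, a primary amine or a carboxylic acid would read at this position also remains open.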